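Triazole-Linked Core Analogues Against SW480 Cells

The compounds below may be only part of what the source reports. "The series", "measured", "known", "first", "only" and "open" are said of these compounds alone.

Measured compounds:
compound 1 `C=C1C[C@]23C[C@@]1(O)CC[C@H]2c1ccc(OS(=O)(=O)c2ccc(C)cc2)c(C)c1[C@@H]3Cn1cc(-c2ccc(Br)cc2)nn1`: > 20000 nM
compound 2 `Cc1c(O)ccc2c1[C@H](Cn1cc(-c3ccccc3)nn1)[C@@]13CC(=O)[C@@](C)(CC[C@@H]21)C3`: > 20000 nM
compound 3 `C=C1C[C@]23C[C@@]1(O)CC[C@H]2c1ccc(O)c(C)c1[C@@H]3Cn1cc(-c2ccc(C(F)(F)F)cc2)nn1`: > 20000 nM

In a functional assay on SW480 cells (Homo sapiens) for cytotoxicity, read by MTT assay, with a stated time of 4 days (on this read-out lower numbers stand for stronger inhibition and higher numbers for weaker inhibition), compound 1 gives > 20000 nM, which is a limit of the assay and not a number. Compound 2 likewise reaches only a limit in this assay, > 20000 nM. Compound 3 also gives only a limit, > 20000 nM. All three values therefore sit at the limit of > 20000 nM in this assay, at which 3 of the 3 values shown sit, so compound 1 stands nowhere apart from the other two.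

Compound 4 `C=C1C[C@]23C[C@@]1(O)CC[C@H]2c1ccc(OS(=O)(=O)c2ccc(C)cc2)c(C)c1[C@@H]3Cn1cc(-c2ccccn2)nn1` is not yet measured. It differs from compound 1 by pyridin-2-yl in place of 4-bromophenyl on an aromatic carbon. For the measured compounds named here, with every value shown at the limit, no step between measured compounds can be read, and no step beyond the scatter is expected. Compound 4 is therefore expected to give 30000 nM, within 10000 nM to 100000 nM, a step that the limit leaves unreadable from compound 1 to compound 4 that is expected to stay within the scatter.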

Compound 4, half-maximal inhibitory concentration: > 20000 nM
Compound 4: only a limit was reported (the forecaster's own chance of this, stated with the estimate: 80%); the middle value lies beyond the limit too.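

No step can be read from compound 1 to compound 4, since both values are limits and not numbers: the limit of > 20000 nM in this assay, at which 4 of the 4 values shown sit.

The compounds shown leave open how far beyond that limit each one lies, and which structural change, if any, would give a readable value.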